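The source may report more compounds than this note shows. Statements on the series, on what has been measured and on what is new or still open speak of the compounds shown alone.

Compound 1, `COc1cc[nH]c1/C=C1\C(=O)Nc2ccc([N+](=O)[O-])c(N3CCC(O)CC3)c21`, gives 46 nM in a functional assay on MDA-MB-435 cells (Homo sapiens) for antiproliferative activity, read by MTT assay, with a stated time of 5 days; on this read-out higher numbers stand for weaker inhibition and lower numbers for stronger inhibition.
Compound 2, `COc1cc[nH]c1/C=C1\C(=O)Nc2ccc([N+](=O)[O-])c(N[C@H]3CC[C@H](N)C3)c21`, gives 61 nM in this assay.

On these two numbers compound 2 cannot be set apart from compound 1: the step of a 1.3-fold higher number from compound 1 to compound 2 (0.12 log units; within the scatter) lies within the scatter, so the two substituents on this aromatic carbon behave alike as far as the data go.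

Compound 3, `COc1cc[nH]c1/C=C1\C(=O)Nc2ccc([N+](=O)[O-])c(N3CCCC(O)C3)c21`, carries 3-hydroxypiperidin-1-yl in place of (3-aminocyclopentyl)amino on an aromatic carbon. Among the compounds with values here, the only measured step bearing on this position is the one from compound 1 to compound 2, where a (3-aminocyclopentyl)amino group replaced 4-hydroxypiperidin-1-yl and the number moved by a 1.3-fold higher number from compound 1 to compound 2 (0.12 log units; within the scatter). Compound 3 brings back a hydroxypiperidin-1-yl group of the kind seen in compound 1. Since that single step stayed within the scatter, no movement beyond the scatter is expected in this assay. For compound 3 the expected step is a 1.2-fold lower number from compound 2 to compound 3 (0.09 log units; within the scatter). Compound 3 is therefore estimated to give 50 nM, within a range from 25 nM to 110 nM.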

Compound 3, half-maximal inhibitory concentration: 250 nM
For compound 3 the middle estimate is 5.0-fold (0.70 log units) below the measured one; the measured number lies above the stated range.
By their numbers in this assay, from the lowest: compounds 1 and 2 (each within the scatter of the next); then compound 3.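

In this assay this position proves sensitive after all: putting 3-hydroxypiperidin-1-yl in place of (3-aminocyclopentyl)amino gives a 4.1-fold higher number from compound 2 to compound 3 (0.61 log units; beyond the scatter) and so leaves the scatter, which the step between compound 1 and compound 2 had not done. The more telling comparison is within the hydroxypiperidine pair, where 3-hydroxypiperidin-1-yl in place of 4-hydroxypiperidin-1-yl gives a 5.4-fold higher number from compound 1 to compound 3 (0.74 log units; beyond the scatter) on the same core. A hydroxypiperidin-1-yl group as such therefore does not fix the number, and the place of the hydroxyl on that ring matters here.

From the compounds shown here alone, what a plain piperidin-1-yl group or a 3-aminopiperidin-1-yl group would give on this aromatic carbon stays open, and with it whether the hydroxyl or the ring carries the change. Nothing available here accounts for the gap between the two hydroxypiperidine compounds.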